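Adding a (benzylamino)methyl group to compound 2

The source may report more compounds than this note shows. Statements on the series, on what has been measured and on what is new or still open speak of the compounds shown alone.

For the measured compounds named here, compound 2 `COc1cc(Nc2nccc3c(-c4ccccc4)n[nH]c23)cc(OC)c1OC` is one of two compounds measured in an assay on HEK293 cells for binding affinity to adenosine receptor A3 (Homo sapiens), read by NanoBRET; a lower number here means tighter binding, a higher number weaker binding. In this assay compound 2 gives 74.1 nM, the highest of the two numbers. The other measured compound, compound 1 `N#Cc1cc2c(-c3ccccc3)n[nH]c2c(Nc2ccccc2)n1`, gives 26.3 nM in this assay; the two compounds differ in more than one place, so their values are taken only as they stand, with compound 2 standing beyond the scatter above compound 1.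

Compound 3 `COc1cc(Nc2nc(CNCc3ccccc3)cc3c(-c4ccccc4)n[nH]c23)cc(OC)c1OC` keeps the shared core and the trimethoxyanilino group of compound 2 and differs from it in one place: (benzylamino)methyl in place of hydrogen on an aromatic carbon. Going by the values given here, no measured pair shows the effect of such a change on the shared core, so the step has to be judged without a precedent. The group is expected to be tolerated with at most a small loss, and the step of a 1.5-fold higher number from compound 2 to compound 3 (0.17 log units; within the scatter) is therefore expected to lie close to the scatter. Compound 3 is accordingly estimated at 110 nM, within a range of 30 nM to 400 nM.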

Compound 3, dissociation constant: 186 nM
Compound 3: the middle estimate sits 1.7-fold (0.23 log units) below what was measured, within the range that was stated.
By their numbers in this assay, from the lowest: compound 1; then compound 2; then compound 3.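

In this assay, for the compounds shown here, the step of a 2.5-fold higher number from compound 2 to compound 3 (0.40 log units; beyond the scatter) gives the first direct reading of a change at this aromatic carbon next to the ring nitrogen. It shows that replacing hydrogen with (benzylamino)methyl, a group of 9 heavy atoms, costs binding beyond the scatter, although the loss is only modest and measurable binding remains. Nothing shown here accounts for this rise.

Compounds 2 and 3 leave open whether a plain methyl or an aminomethyl group on the same carbon would give a smaller step, and whether a longer chain ending in the same carbon-only aromatic ring would give a larger one. They also leave open whether (benzylamino)methyl would have a similar effect alongside a different anilino group.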